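Swapping one chloro for hydrogen on compound 3

The source may hold more compounds than are shown below. What is called first, only, known or untested is meant among the compounds shown, and "the series" means these compounds.

compound 1 `O=S(=O)(Nc1ccc(-c2nc3cc(NS(=O)(=O)c4ccc(Br)cc4)ccc3o2)cc1)c1ccc(Br)cc1`: 18000 nM
compound 2 `COc1ccc(S(=O)(=O)Nc2ccc3oc(-c4ccc(NC(=O)c5ccc(Cl)s5)cc4)nc3c2)cc1`: > 100000 nM (a limit of the assay, not a number)
compound 3 `O=C(Nc1ccc(Sc2nc3ccccc3s2)c(Cl)c1)c1cccc(Br)c1O`: > 100000 nM (a limit of the assay, not a number)

These values come from an ADME assay on FHC cells (Homo sapiens) for cytotoxicity, read by resazurin assay, with a stated time of 48 h; on this read-out higher numbers stand for lower toxicity in this test and lower numbers for higher toxicity in this test. Only compound 1 gives a true number there. Going by these compounds, compound 3 stands at the limit of > 100000 nM in this assay, at which 2 of the 3 values shown sit, so its exact value is unknown. Compound 4 `O=C(Nc1ccc(Sc2nc3ccccc3s2)cc1)c1cccc(Br)c1O` is compound 3 with one change: hydrogen in place of chloro on an aromatic carbon. The hydrogen sits ortho to a large group and meta to a large group. For the measured compounds named here, no measured pair of compounds shows this swap, so the data give no size for it. No change beyond the usual scatter is expected, in either direction. The estimated step is a number no higher from compound 3 to compound 4 (the limit leaves the size open). The estimate in this assay for compound 4 is 100000 nM, with an expected range of 40000 nM to 250000 nM.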

Compound 4, half-maximal cytotoxic concentration: 59000 nM
Compound 4: middle estimate off by 1.7-fold (0.23 log units), on the high side, and the stated range covers the measured number.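

In this assay, hydrogen in place of chloro gives an at least 1.6-fold lower number from compound 3 to compound 4 (0.22 log units; that floor lies within the scatter). For the compounds shown here, this is the first single swap that can be read here, and compound 4 gives a true number, 59000 nM, so the position now has a measured reference point. The real size of the step stays unknown because compound 3 sits at a limit, not a number: the limit of > 100000 nM in this assay, at which 2 of the 4 values shown sit.

Going by these compounds, how other groups at this position, such as a methyl or an amine, would move the number remains open. So does whether this swap behaves the same way on other cores.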